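This account rests on a few compounds, and the source may have more. Where it says the series, first, only, none or still open, it means among the compounds named here.

Measured so far in an assay on HEK293 cells for inhibition of neurogenic locus notch homolog protein 1 (Homo sapiens), read by a luciferase reporter and resazurin assay, with a stated time of 16 h; on this read-out higher numbers stand for weaker inhibition and lower numbers for stronger inhibition:
compound 1 `CC1=C(C(=O)OCC2CCN(C(=O)OC(C)(C)C)CC2)[C@@H](c2cccc(Br)c2)C2=C(CC(C)(C)CC2=O)N1` — 2590 nM
compound 2 `CC1=C(C(=O)OCC2CCN(C(=O)OC(C)(C)C)CC2)[C@H](c2cccc(Br)c2)C2=C(CC(C)(C)CC2=O)N1` — 130 nM
compound 3 `CC1=C(C(=O)OCC2CCN(C(=O)OC(C)(C)C)CC2)C(c2cccc(Br)c2)C2=C(CC(C)(C)CC2=O)N1` — 360 nM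

Compound 3 stands second highest of the three numbers in this assay. The two compounds drawn with a defined configuration at the saturated ring carbon frame it: a 20-fold lower number from compound 1 to compound 2 (1.30 log units; beyond the scatter), and for compound 3, drawn without a configuration at that carbon, a 2.8-fold higher number from compound 2 to compound 3 (0.44 log units; beyond the scatter) and a 7.2-fold lower number from compound 1 to compound 3 (0.86 log units; beyond the scatter). Those three steps rest on (the fact that compounds 1 and 2 differ only in the configuration as drawn), the fact that one of compounds 1 and 3 is drawn with a defined configuration and the other without, at the place where they differ and (the fact that one of compounds 2 and 3 is drawn with a defined configuration and the other without, at the place where they differ); they concern configuration only and say nothing about the aryl group.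

Compound 4 `CC1=C(C(=O)OCC2CCN(C(=O)OC(C)(C)C)CC2)C(c2cc(Cl)cc(Cl)c2)C2=C(CC(C)(C)CC2=O)N1` keeps the undefined configuration of compound 3 and changes the aryl group: 3,5-dichlorophenyl in place of 3-bromophenyl on a saturated ring carbon. Within the data shown here, no measured step in this set touches the aryl group, so there is no direct precedent for this change. With nothing beyond the scatter to point either way, the expected step in this assay is a 1.2-fold lower number from compound 3 to compound 4 (0.08 log units; within the scatter), small and uncertain in direction. Compound 4 is therefore estimated at 300 nM in this assay, with a range from 90 nM to 1000 nM.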

Compound 4, half-maximal inhibitory concentration: 640 nM
Beside the measured number, compound 4's estimate is 2.1-fold (0.33 log units) below it; the measured number falls inside the stated range.
By their numbers in this assay, from the lowest: compound 2; then compounds 3 and 4 (each within the scatter of the next); then compound 1.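

In this assay, the aryl group on a saturated ring carbon of the six-membered non-aromatic ring with 1 nitrogen now has its first reading: 3,5-dichlorophenyl in place of 3-bromophenyl gives a 1.8-fold higher number from compound 3 to compound 4 (0.25 log units; within the scatter), so the two aryl groups cannot be told apart on this read-out. This position therefore accepts two chlorine atoms in place of one bromine atom with no change beyond the scatter, a much smaller step than the one that configuration alone gives in the same assay, a 20-fold lower number from compound 1 to compound 2 (1.30 log units; beyond the scatter). No available evidence bears on the aryl change, as everything at hand concerns configuration only.

On these data alone, compound 3 and compound 4 are both drawn without a configuration at the aryl-bearing carbon, so it remains open whether 3,5-dichlorophenyl would show the same split between the two drawn configurations as 3-bromophenyl does in compound 1 and compound 2. Also open is how this position responds to an aryl group without halogen, such as a pyridyl ring or a phenyl ring carrying a carboxylic acid or an amine, since both aryl groups shown here carry only halogen substituents.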